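The source may report more compounds than this note shows. Statements on the series, on what has been measured and on what is new or still open speak of the compounds shown alone.

In an ADME assay on Vero cells (Chlorocebus sabaeus) for cytotoxicity, read by MTT assay (a lower number here means that less compound is tolerated, a higher number that more compound is tolerated), compound 1 `COc1ccc(-c2nc3cnccn3c2Nc2cc(OC)c(OC)c(OC)c2)cc1O` gives 50000 nM and compound 2 `COc1cc(Nc2c(-c3ccc(Cl)cc3)nc3cnccn23)cc(OC)c1OC` gives 32000 nM. Among the measured compounds shown here, these are the only two numbers so far, and they sit within the usual scatter of each other, so compound 1 stands level with its one neighbour. Compound 3 `COc1cc(Nc2c(-c3ccc(F)cc3)nc3cnccn23)cc(OC)c1OC` differs from compound 1 by one change: 4-fluorophenyl in place of 3-hydroxy-4-methoxyphenyl on an aromatic carbon. Here 4-fluorophenyl takes the place of 3-hydroxy-4-methoxyphenyl on an aromatic carbon of the five-membered aromatic ring. For the measured compounds named here, the one measured step that bears on this swaps the same group at the same place for 4-chlorophenyl, and it is a 1.6-fold lower number from compound 1 to compound 2 (0.19 log units; within the scatter). A single step is thin evidence, but it gives no reason to expect a change beyond the scatter in this assay. The expected step is a 1.4-fold lower number from compound 1 to compound 3 (0.15 log units; within the scatter). For compound 3 the estimated value is 35000 nM, with a range of 16000 nM to 70000 nM.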

Compound 3, concentration lethal to 50% of the cells: 48000 nM
For compound 3 the middle estimate is 1.4-fold (0.14 log units) below the measured one; measured number inside the range.
By their numbers in this assay, from the lowest: compounds 2, 3 and 1 (each within the scatter of the next).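

In this assay, the change to 4-fluorophenyl gives a 1.0-fold lower number from compound 1 to compound 3 (0.02 log units; within the scatter), so a second replacement at this aromatic carbon of the five-membered aromatic ring also stays within the scatter, even though the 3-hydroxy-4-methoxyphenyl group that leaves has a hydrogen-bond donor and 4-fluorophenyl has none. The new pair also adds a change on the phenyl ring itself: fluoro in place of chloro gives a 1.5-fold higher number from compound 2 to compound 3 (0.18 log units; within the scatter), again within the scatter, so none of the three compounds separates from the others in this assay. No measurement here explains why the numbers stay so close.

On these data alone, all three compounds carry a six-membered aromatic ring of carbon only at this place, so the effect of an amine, a carboxylic acid or a longer chain there remains open. As far as these compounds go, what a change elsewhere on the shared core would do also remains open.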